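Compound 2 and its ring exchange to compound 3

A few compounds are considered here, and "the series" means these few. Any claim that something is new, unique, unknown or untested is made for them only; others in the source may bear on it.

In a functional assay on A549 cells (Homo sapiens) for cytotoxicity (on this read-out higher numbers stand for an effect only at larger amounts of compound and lower numbers for an effect already at smaller amounts), compound 1 `C/C(=C\CCc1ccoc1)C[C@@H]1C=C(C/C=C/c2ccoc2)C(=O)O1` gives 7.9 ug/mL, a measured number that shows an effect on these cells. Compound 2 `COC1C=C(CCC/C(C)=C/C=C/[C@@H](C)CC/C=C(/C)C[C@H]2OC(=O)C(C)=C2O)C(=O)O1` is reported as > 30 ug/mL, which is a limit of the assay and not a number. Its true position on the scale is therefore unknown.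

Compound 3 `CC1=C(O)[C@@H](C/C(C)=C\CC[C@H](C)/C=C/C=C(\C)CCCC2=CCN(CC(=O)O)C2=O)OC1=O` differs from compound 2 in one place: a group of 10 heavy atoms (6 carbon, 1 nitrogen, 3 oxygen; one five-membered non-aromatic ring with 1 hetero atom) in place of a group of 8 heavy atoms (5 carbon, 3 oxygen; one five-membered non-aromatic ring with 1 hetero atom), on a saturated chain carbon, three bonds along the chain from a double-bonded chain carbon. Both the leaving and the entering group hold a five-membered non-aromatic ring, but only the entering group contains nitrogen. Going by the values given here, no measured pair shows what an exchange of this kind does, so there is no known step to carry over. In this assay, no shift beyond the usual scatter is expected, and compound 3 will most likely also be reported as a limit. The expected step is a step that the limit leaves unreadable from compound 2 to compound 3. Compound 3 is estimated at 35 ug/mL, within an expected range of 14 ug/mL to 90 ug/mL.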

Compound 3, concentration for half-maximal effect: > 30 ug/mL
Compound 3: only a limit was reported (the forecaster's own chance of this, stated with the estimate: 70%); the middle value is on the limit's open side.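

No step can be read between compound 2 and compound 3, since each is reported only as a limit of the assay and not as a number: the limit of > 30 ug/mL in this assay, at which 2 of the 3 values shown sit.

The compounds shown leave open where either one truly lies in this assay, and what the exchange of groups does there.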